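From a Pyridylmethyl Amide to a Methyl Ester

The source may hold more compounds than are shown below. What is called first, only, known or untested is meant among the compounds shown, and "the series" means these compounds.

Compound 1 `O=C(NCCO)c1ccc2ccc(C(=O)c3ccccc3)c-2cc1` gives 6 ug/mL in a physicochemical assay for solubility, with a stated time of 24 h, at pH 4.5; on this read-out lower numbers stand for lower solubility and higher numbers for higher solubility.
Compound 2 `O=C(NCc1cccnc1)c1ccc2ccc(C(=O)c3ccccc3)c-2cc1` gives < 1 ug/mL in this assay, which is a limit of the assay and not a number.
Compound 3 `O=C(Cn1ccccc1=O)Nc1cc2cccccc-2c1` gives 2 ug/mL in this assay.

Compound 2 therefore stands at the bottom of the numbers shown, sitting at the limit of < 1 ug/mL in this assay, at which 1 of the 3 values shown sits. Within the data shown here, the only measured step on the shared core is an at least 6.0-fold lower number from compound 1 to compound 2 (0.77 log units; beyond the scatter), and it ends at that limit. Compound 4 `COC(=O)c1ccc2ccc(C(=O)c3ccccc3)c-2cc1` differs from compound 2 by methoxy in place of ((pyridin-3-yl)methyl)amino on a carbonyl carbon. Among the measured compounds shown here, no measured step exchanges an amide for an ester, so that step bears on the new change only indirectly: it shows that this core already sits low in this assay even with the more hydroxymethyl-bearing side chain of compound 1, and compound 3 on a different core is likewise low. The removal of the ring and the donor is expected to move compound 4 little beyond the scatter, and a further fall could not be seen past the limit. Compound 4 is therefore estimated at 1 ug/mL, between 0.3 ug/mL and 4 ug/mL. The expected step is a number no lower from compound 2 to compound 4 (the limit leaves the size open).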

Compound 4, solubility: < 1 ug/mL
Compound 4 gave a limit, no number; the forecaster's own chance of this, stated with the estimate: 50%; the middle value lies on the limit itself.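

In this assay, methoxy in place of (2-hydroxyethyl)amino on a carbonyl carbon gives an at least 6.0-fold lower number from compound 1 to compound 4 (0.77 log units; beyond the scatter), so the shared core reaches the bottom of the read-out without the pyridin-3-yl ring. Compound 2 and compound 4 each give a limit and not a number, so the step between them cannot be read: the limit of < 1 ug/mL in this assay, at which 2 of the 4 values shown sit.

Among the compounds on the shared core, only compound 1 gives a readable number, 6 ug/mL.

On these data alone, whether a carboxylic acid or an amide with a longer chain ending in a morpholine ring on this carbonyl carbon would give a number higher than that of compound 1 stays open. Also open, as far as these compounds go, is whether the methyl ester and the pyridylmethyl amide differ at all in this assay.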